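Benzoxazole sulfonamides: fluoro to trifluoromethyl on the sulfonyl ring

A few compounds are considered here, and "the series" means these few. Any claim that something is new, unique, unknown or untested is made for them only; others in the source may bear on it.

Of the compounds shown here, three have been measured in an assay on isolated protein for inhibition of malate dehydrogenase, mitochondrial (Sus scrofa), with stated times of 45 min and 30 min; on this read-out lower numbers stand for stronger inhibition and higher numbers for weaker inhibition. Compound 1 `O=S(=O)(Nc1ccc2oc(-c3ccccc3)nc2c1)c1cccc(C(F)(F)F)c1` and compound 2 `O=S(=O)(Nc1ccc2oc(-c3ccccc3)nc2c1)c1cccc(F)c1` share one core; compound 3 `O=S(=O)(Nc1ccc(-c2nc3ccccc3o2)cc1)c1ccc(F)cc1` carries the sulfonamide on a different core, and the difference between the two cores is not broken down here. In this assay compound 1 gives only a limit, > 63000 nM. Compound 2 likewise gives only a limit in this assay, > 63000 nM. For compound 3 this assay also reports only a limit, > 63000 nM. All three values sit at the limit of > 63000 nM in this assay, at which 3 of the 3 values shown sit, so no order among them can be read.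

Within the data shown here, the one change that is measured is trifluoromethyl in place of fluoro on an aromatic carbon. The step it made is a step that the two limits leave unreadable from compound 2 to compound 1, and its size cannot be read because both ends of it are limits.

Compound 4 `O=S(=O)(Nc1ccc(-c2nc3ccccc3o2)cc1)c1ccc(C(F)(F)F)cc1` has not yet been measured in this assay. It differs from compound 3 by trifluoromethyl in place of fluoro on an aromatic carbon. This is the same kind of change as that from compound 2 to compound 1, but not the same: there the group enters meta to a large group, here para to a large group.

What is expected rests on the limits of compound 3 and of the pair compound 2 and compound 1. Since the measured step that the two limits leave unreadable from compound 2 to compound 1 gave no readable movement, the step that the limit leaves unreadable from compound 3 to compound 4 is expected to be small or unreadable. Compound 4 is thus expected to give a value near 100000 nM in this assay, most probably again as a limit rather than a number, with an expected range from 30000 nM to 400000 nM.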

Compound 4, half-maximal inhibitory concentration: > 63000 nM
Compound 4 ended at the assay's limit; the forecaster's own chance of this, stated with the estimate: 85%; the middle value is on the limit's open side.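

No new step can be read in this assay from compound 3 to compound 4, since both ends are limits of the assay, as they are from compound 2 to compound 1: the limit of > 63000 nM in this assay, at which 4 of the 4 values shown sit.

The compounds shown leave open whether trifluoromethyl in place of fluoro moves inhibition on either core, and whether any compound of the series gives a readable number in this assay.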